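What compound 2 may gain by losing one group

The compounds below may be only part of what the source reports. "The series", "measured", "known", "first", "only" and "open" are said of these compounds alone.

compound 1 `COc1cccc(-c2cccc(NC(=O)C(Cl)Cl)c2)c1`: 4310 nM
compound 2 `O=C(Nc1cccc(-c2cccc(NC(=O)C(Cl)Cl)c2)c1)C(Cl)Cl`: 47900 nM

In a functional assay on A549 cells (Homo sapiens) for cytotoxicity, read by MTT assay, with a stated time of 68 h (on this read-out higher numbers stand for weaker inhibition and lower numbers for stronger inhibition), compound 2 gives 47900 nM, the higher of the two numbers and so the weaker inhibition. Compound 1 lies well beneath it, a gap beyond the scatter.

Compound 3 `O=C(Nc1cccc(-c2ccccc2)c1)C(Cl)Cl` differs from compound 2 in one place, with hydrogen in place of ((dichloromethyl)carbonyl)amino on an aromatic carbon.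

Going by the values given here, only one measured step bears on this change: an 11-fold higher number from compound 1 to compound 2 (1.05 log units; beyond the scatter). There, the same group entered in place of methoxy, and the number rose by a large amount. Compound 3 loses that group again, which points back towards compound 1 and its 4310 nM. Hydrogen is not methoxy, however, and no measured compound shows hydrogen at this place, so the return may be only partial.

The step expected in this assay is therefore fairly large and towards stronger inhibition: a 6.0-fold lower number from compound 2 to compound 3 (0.78 log units; beyond the scatter). The estimate for compound 3 is 8000 nM, with an expected range of 2500 nM to 25000 nM.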

Compound 3, half-maximal inhibitory concentration: 8900 nM
Compound 3: the middle estimate sits 1.1-fold (0.05 log units) below what was measured; measured number inside the range.
By their numbers in this assay, from the lowest: compound 1; then compound 3; then compound 2.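

The second ((dichloromethyl)carbonyl)amino group now has a direct comparison with plain hydrogen: in this assay, replacing it with hydrogen gives a 5.4-fold lower number from compound 2 to compound 3 (0.73 log units; beyond the scatter) and so shows that the weaker inhibition of compound 2 does not depend on methoxy being the comparison group. Hydrogen and methoxy also do not match at this place, since hydrogen in place of methoxy gives a 2.1-fold higher number from compound 1 to compound 3 (0.31 log units; beyond the scatter) and this modest step still lies beyond the scatter. The three compounds therefore rank methoxy, then hydrogen, then ((dichloromethyl)carbonyl)amino, from stronger to weaker inhibition, but no accompanying measurement speaks to the reason for this order.

On these data alone, three groups at one place give an order rather than a rule, so it remains open whether a longer chain such as ethoxy would extend the small advantage of methoxy over hydrogen, or how a hydroxyl group, an amine or a carboxylic acid would fit into the order. As far as these compounds go, all three compounds also keep one ((dichloromethyl)carbonyl)amino group, so what that remaining group contributes to the cytotoxicity stays unknown.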